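The source may hold more compounds than are shown below. What is called first, only, known or untested is meant among the compounds shown, and "the series" means these compounds.

Measured so far:
Compound 1, `c1ccc(-c2ccncc2)c(OCC2=NCCN2)c1` — < 100000 nM in a functional assay for activation of Alpha-1B adrenergic receptor (Homo sapiens), read by calcium flux; a higher number here means that more compound is needed for the effect, a lower number that less compound is needed; this value is a limit of the assay, not a number.
Compound 2, `Cc1ccoc1-c1ccccc1OCC1=NCCN1` — < 100000 nM; this value too is a limit of the assay.

Both measured compounds sit at the limit of < 100000 nM in this assay, at which 2 of the 2 values shown sit, so the step that the two limits leave unreadable from compound 1 to compound 2, in which 3-methylfuran-2-yl stands in place of pyridin-4-yl on an aromatic carbon, cannot be read from these two values. Where compound 2 stands is therefore known only as a limit, with no number behind it.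

Compound 3, `Cc1ccc(-c2ccccc2OCC2=NCCN2)s1`, is not yet measured. It differs from compound 2 by 5-methylthiophen-2-yl in place of 3-methylfuran-2-yl on an aromatic carbon. No measured step bears on this change: the only step shown is unreadable, and nothing else is known about compound 2 beyond its limit. The step from compound 2 to compound 3 is estimated as a step that the limit leaves unreadable from compound 2 to compound 3. For compound 3 an estimate of 15000 nM in this assay is expected, with a range from 1000 nM to 100000 nM.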

Compound 3, half-maximal effective concentration: < 100000 nM
Compound 3 was reported as a limit (the forecaster's own chance of this, stated with the estimate: 65%); the middle value lies beyond the limit too.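

The steps among compound 1, compound 2 and compound 3 cannot be read, since all three values are limits of the assay: the limit of < 100000 nM in this assay, at which 3 of the 3 values shown sit.

The compounds shown leave open what number lies behind each limit, and whether pyridin-4-yl, 3-methylfuran-2-yl and 5-methylthiophen-2-yl differ in effect at all.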